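The compounds below may be only part of what the source reports. "The series", "measured", "known", "first", "only" and "open" are said of these compounds alone.

Working notes on the ester series. Compound 1 `CCCCOC(=O)Cc1c(C(C)C)nc(CCCC)n(Cc2ccc(-c3ccccc3-c3noc(=O)[nH]3)cc2)c1=O` gives 21.6% in an ADME assay on microsomes from liver (Mus musculus) for metabolic stability, with a stated time of 30 min; a lower number here means that less of the compound is left, a higher number that more of the compound is left. Compound 2 `CCCCc1nc(C)c(CC(=O)OCC)c(=O)n1Cc1ccc(-c2ccccc2-c2noc(=O)[nH]2)cc1` has two entries in this assay, 12.9%; 78.4% (2 entries); the spread between them, (the several entries of compound 2 in this assay, 12.9%; 78.4% (2 entries)), is far wider than the usual scatter, so no single number can stand for compound 2. Compound 3 `CCCCc1nc(C)c(CC(=O)OC(C)C)c(=O)n1Cc1ccc(-c2ccccc2-c2noc(=O)[nH]2)cc1` gives 4% in this assay, the lower of the two single numbers in the set; the nearest single number is that of compound 1, which lies beyond the scatter above it, and compound 2 stands apart without a single number.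

Compound 4 `CCCCOC(=O)Cc1c(C)nc(CCCC)n(Cc2ccc(-c3ccccc3-c3noc(=O)[nH]3)cc2)c1=O` is not yet measured in this assay. It differs from compound 3 in one place: butyl in place of isopropyl on an oxygen next to a carbonyl group. Going by the values given here, no measured pair carries this same change on an otherwise identical core, so the size of the step is not known from data. Compound 1 carries the butyl ester together with a different group at the other varied position and gives 21.6%; compound 3 carries the isopropyl ester and gives 4%. The step from compound 3 to compound 4 is expected to be modest and upward, a number 8 percentage points higher from compound 3 to compound 4 (within the scatter), with wide uncertainty given the spread seen for compound 2 in the several entries of compound 2 in this assay, 12.9%; 78.4% (2 entries). Compound 4 is estimated at 12%, within 3% to 30%.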

Compound 4, percent of the compound remaining: 10.2%
The estimate for compound 4 lay 1.8 percentage points above the measured number; the range from low to high includes it.
By their numbers in this assay, from the lowest: compounds 3 and 4 (each within the scatter of the next); then compound 1.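

In this assay butyl in place of isopropyl on an oxygen next to a carbonyl group gives a number 6.2 percentage points higher from compound 3 to compound 4 (within the scatter) on an otherwise identical core, so this place now has a direct reading, and the change does not separate the two esters. The other varied place also has its first direct reading: with the butyl ester held constant, methyl in place of isopropyl on an aromatic carbon gives a number 11.4 percentage points lower from compound 1 to compound 4 (beyond the scatter) in the same assay. In these two pairs, only the change on the aromatic carbon lies beyond the scatter, and each reading rests on a single pair of compounds.

On these data alone, it remains open how this assay would read for a carboxylic acid in place of the ester, or for a longer chain such as octyl on the same oxygen. Any step to compound 2 cannot be read, so the ethyl ester cannot yet be placed beside the isopropyl and butyl esters: the several entries of compound 2 in this assay, 12.9%; 78.4% (2 entries).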